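Notes on a phenyl-for-fluoro exchange in the series

The compounds below may be only part of what the source reports. "The series", "measured", "known", "first", "only" and "open" are said of these compounds alone.

In a functional assay on HeLa cells (Homo sapiens) for cytotoxicity, read by MTT assay, with a stated time of 48 h, tested at 50 uM (a higher number here means a stronger effect of the compound at the concentration tested, a lower number a weaker effect), compound 1 `CSc1ccc(/C=N/n2c(Cc3ccc(S(C)(=O)=O)cc3)n[nH]c2=S)cc1` gives 57.5% and compound 2 `CS(=O)(=O)c1ccc(Cc2n[nH]c(=S)n2/N=C/c2ccc(F)cc2)cc1` gives 26.3%. Among the compounds with values here, the only step in hand is a number 31.2 percentage points lower from compound 1 to compound 2 (beyond the scatter). Within the data shown here, compound 2 therefore stands lowest of the two numbers measured so far, with compound 1 as its nearest neighbour, beyond the scatter. Compound 3 `CS(=O)(=O)c1ccc(Cc2n[nH]c(=S)n2/N=C/c2ccc(-c3ccccc3)cc2)cc1` is not yet measured and differs from compound 2 as follows: phenyl in place of fluoro on an aromatic carbon. Among the measured compounds shown here, no measured step bears directly on this exchange; the one known step, which swapped a group on the same aromatic carbon, shows that a change there can move this assay by a large amount, so a step beyond the scatter is plausible in either direction, and the expectation here is an upward one of a number 18.7 percentage points higher from compound 2 to compound 3 (beyond the scatter). Compound 3 is accordingly estimated at 45%, within an expected range from 20% to 70%.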

Compound 3, a percentage reported as activity, at one concentration (the size of the read-out at that concentration, not a potency): 61.6%
Beside the measured number, compound 3's estimate is 16.6 percentage points below it; the measured number falls inside the stated range.
By their numbers in this assay, from the lowest: compound 2; then compounds 1 and 3 (each within the scatter of the next).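

In this assay, the exchange gives a number 35.3 percentage points higher from compound 2 to compound 3 (beyond the scatter), so this aromatic carbon tolerates a group of six heavy atoms with its own ring, and fluoro is not simply replaced by a comparable group. The second comparison gives a number 4.1 percentage points higher from compound 1 to compound 3 (within the scatter), which leaves phenyl and methylsulfanyl indistinguishable here, while fluoro alone stands apart from both across the three compounds shown. No measurement at hand offers a reason for either step.

Three groups cannot show whether the number in this assay tracks the size of the group or something else about it, and an amine or a carboxylic acid on the same aromatic carbon would test that further. A read-out at a single concentration also tells only the size of the effect of compound 1 and compound 3 at that concentration.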